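Benzyl for Isopropyl: Expected Effect on Metabolic Stability

The source may hold more compounds than are shown below. What is called first, only, known or untested is meant among the compounds shown, and "the series" means these compounds.

Compound 1, `CC(C)N/C(=N\c1nccn1C(C)C)Nc1ccc(Cl)c(Cl)c1`: 0.375 h
Compound 2, `CC(C)N/C(=N\c1nccn1Cc1ccccc1)Nc1ccc(Cl)c(Cl)c1`: 0.267 h
Compound 3, `CC(C)C(=O)N/C(=N/c1nccn1C(C)C)Nc1ccc(Cl)c(Cl)c1`: > 1 h

All three were run in an in vitro ADME assay on microsomes from liver (Homo sapiens) for metabolic stability, read by LC-MS, tested at 1 uM; on this read-out lower numbers stand for a shorter-lived compound and higher numbers for a longer-lived compound. Compound 1 gives 0.375 h and compound 2 gives 0.267 h; the step between them, a 1.4-fold lower number from compound 1 to compound 2 (0.15 log units; within the scatter), comes from the change (benzyl in place of isopropyl on an aromatic nitrogen). Compound 3 is reported only as a limit of the assay, > 1 h, which is the limit of > 1 h in this assay, at which 1 of the 3 values shown sits. The cores of compound 1 and compound 3 differ, but that difference is not broken down here. Within the data shown here, compound 4, `CC(C)C(=O)N/C(=N/c1nccn1Cc1ccccc1)Nc1ccc(Cl)c(Cl)c1`, has not been measured; it differs from compound 3 by benzyl in place of isopropyl on an aromatic nitrogen, the same change at the same place as the one from compound 1 to compound 2. Given the earlier step of a 1.4-fold lower number from compound 1 to compound 2 (0.15 log units; within the scatter), compound 4 is expected to show a step that the limit leaves unreadable from compound 3 to compound 4. Compound 4 is therefore estimated at 1.2 h, between 0.5 h and 2.5 h, and may again be reported only as a limit.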

Compound 4, half-life: 0.328 h
Estimate against measurement, compound 4: 3.7-fold (0.56 log units) above, and the stated range ends above it.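

In this assay, benzyl in place of isopropyl on the aromatic nitrogen gives an at least 3.0-fold lower number from compound 3 to compound 4 (0.48 log units; beyond the scatter). On these data alone, for compound 3, > 1 h is a limit of the assay and not a number, so the full size of this step is unknown. The data therefore show that the change can lower the half-life clearly on the core of compound 3, but not that it acts more strongly there than on the core of compound 1: the same change on two cores in this assay, a 1.4-fold lower number (0.15 log units; within the scatter) from compound 1 to compound 2 and an at least 3.0-fold lower number (0.48 log units; beyond the scatter) from compound 3 to compound 4; the limit leaves it open whether they differ

The compounds shown leave open how smaller or longer groups on this nitrogen, such as a methyl or a longer carbon chain, would behave. They also leave open whether a third core would give a similar step.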